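The source may report more compounds than this note shows. Statements on the series, on what has been measured and on what is new or still open speak of the compounds shown alone.

Notes on the series. Compound 1 `Cn1c(=O)c2[nH]c(SCC(=O)c3ccc(Cl)cc3)nc2n(C)c1=O` and compound 2 `Cn1c(=O)c2[nH]c(SCC(=O)c3ccc(Br)cc3)nc2n(C)c1=O` share a core and differ only by bromo in place of chloro on an aromatic carbon. In a functional assay on PANC-1 cells (Homo sapiens) for inhibition, read by MTT assay, with a stated time of 48 h (a higher number here means a weaker inhibitor, a lower number a stronger inhibitor), compound 1 gives 7200 nM, and compound 2 gives 7400 nM; the step of a 1.0-fold higher number from compound 1 to compound 2 (0.01 log units; within the scatter) is within the scatter, so the two values cannot be ordered.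

Compound 3 `Cn1c(=O)c2[nH]c(SC/C(=N/O)c3ccc(Cl)cc3)nc2n(C)c1=O` carries a different core; how the two cores differ is not broken down here. In this assay compound 3 gives 1300 nM, the lowest of the three measured values, with the nearest measured compound, compound 1, beyond the scatter above it.

Compound 4 `Cn1c(=O)c2[nH]c(SC/C(=N/O)c3ccc(Br)cc3)nc2n(C)c1=O` is not yet measured. It differs from compound 3 by bromo in place of chloro on an aromatic carbon, the same change as between compound 1 and compound 2, at the same place in both pairs. Because a 1.0-fold higher number from compound 1 to compound 2 (0.01 log units; within the scatter) lay within the scatter, the step from compound 3 to compound 4 is expected to be of the same size, a 1.1-fold higher number from compound 3 to compound 4 (0.03 log units; within the scatter). Compound 4 is therefore estimated at 1400 nM in this assay, with a range of 600 nM to 3200 nM.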

Compound 4, half-maximal inhibitory concentration: 1700 nM
Beside the measured number, compound 4's estimate is 1.2-fold (0.08 log units) below it, and the stated range covers the measured number.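

In this assay, bromo in place of chloro on an aromatic carbon gives a 1.3-fold higher number from compound 3 to compound 4 (0.12 log units; within the scatter), so the two values cannot be ordered. Set beside the earlier step on the core of compound 1, the same change reads alike on both cores: the same change on two cores in this assay, a 1.0-fold higher number (0.01 log units; within the scatter) from compound 1 to compound 2 and a 1.3-fold higher number (0.12 log units; within the scatter) from compound 3 to compound 4, 1.3-fold (0.10 log units) apart, within the scatter of two such steps

Within these two pairs, then, the 4-chlorophenyl to 4-bromophenyl change carries from one core to the other with no readable effect on the number in either; this does not show that it would stay without effect on any further core or in any other assay, and it gives no reason for the result.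

All four compounds carry chloro or bromo at this place on the ring, which leaves open how fluoro, methoxy, an amine or a carboxylic acid there would read in this assay. Also open, going by these compounds, is whether a longer chain in place of either methyl group on the shared core would change the number.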